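The source may hold more compounds than are shown below. What is called first, only, known or untested is meant among the compounds shown, and "the series" means these compounds.

Working notes on the series. Compound 1 `COc1ccc2[nH]c(=O)c(-c3nc4cc(C)c(C)cc4[nH]3)cc2c1` and compound 2 `Cc1ccc2[nH]c(=O)c(-c3nc4cc(C)c(C)cc4[nH]3)cc2c1` carry the same core and differ only at one aromatic carbon, where a methyl replaces a methoxy. In a functional assay on HepG2 cells (Homo sapiens) for cytotoxicity, read by MTT assay, with a stated time of 48 h (on this read-out lower numbers stand for stronger inhibition and higher numbers for weaker inhibition), compound 1 gives > 100000 nM, which is a limit of the assay and not a number. In this assay compound 2 gives > 100000 nM, again a limit rather than a number. Among the compounds with values here, the one measured step, a step that the two limits leave unreadable from compound 1 to compound 2, therefore cannot be read for size or direction; both values sit at the limit of > 100000 nM in this assay, at which 2 of the 2 values shown sit.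

Where compound 2 stands: on the numbers shown it is known only as a limit, with no measured value of its own.

Compound 3 `Cc1cc2nc(-c3cc4ccccc4[nH]c3=O)[nH]c2cc1C` differs from compound 2 by hydrogen in place of methyl on an aromatic carbon. Within the data shown here, the only measured step that bears on this change is the unreadable one between compound 1 and compound 2, so no measured size of step is available to carry over. Compound 3 is expected to remain at the limit of this assay, a step of a number no higher from compound 2 to compound 3 (the limit leaves the size open) being the estimate. The estimate for compound 3 in this assay is 100000 nM, with a range from 30000 nM to 300000 nM.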

Compound 3, half-maximal inhibitory concentration: > 100000 nM
Compound 3: a limit, no number; the forecaster's own chance of this, stated with the estimate: 85%; the middle value lies on the limit itself.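

In this assay compound 3 gives > 100000 nM, a limit and not a number. The steps from compound 1 and compound 2 to compound 3 therefore cannot be read for size or direction: the limit of > 100000 nM in this assay, at which 3 of the 3 values shown sit.

The compounds shown leave open whether methoxy, methyl or hydrogen at this aromatic carbon makes any difference in this assay.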